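Hydroxy for Trifluoromethyl on Two Related Cores

This account rests on a few compounds, and the source may have more. Where it says the series, first, only, none or still open, it means among the compounds named here.

Compound 1 `COc1ccc(-c2nn(-c3ccccc3)cc2C(=O)/C=C\Nc2ccc(C(F)(F)F)cc2)cc1` is the starting point. In a functional assay on HT-29 cells (Homo sapiens) for antiproliferative activity, read by MTT assay, with a stated time of 48 h (on this read-out lower numbers stand for stronger inhibition and higher numbers for weaker inhibition), compound 1 gives 9870 nM. Compound 2 `COc1ccc(-c2nn(-c3ccccc3)cc2C(=O)/C=C\Nc2ccc(O)cc2)cc1` differs from it by one change, (hydroxy in place of trifluoromethyl on an aromatic carbon), and in this assay compound 2 gives 2460 nM. The measured step is a 4.0-fold lower number from compound 1 to compound 2 (0.60 log units; beyond the scatter).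

Compound 3 `COc1cc(-c2nn(-c3ccccc3)cc2C(=O)/C=C\Nc2ccc(C(F)(F)F)cc2)cc(OC)c1OC` keeps the trifluoromethyl group but differs from compound 1 in its core by 3,4,5-trimethoxyphenyl in place of 4-methoxyphenyl on an aromatic carbon. For compound 3 this assay reports only a limit, > 50000 nM. The step of an at least 5.0-fold higher number from compound 1 to compound 3 (0.70 log units; beyond the scatter) is therefore bounded by the limit of > 50000 nM in this assay, at which 1 of the 3 values shown sits, and the true position of compound 3 is open.

Compound 4 `COc1cc(-c2nn(-c3ccccc3)cc2C(=O)/C=C\Nc2ccc(O)cc2)cc(OC)c1OC` stands to compound 3 as compound 2 stands to compound 1: the change is hydroxy in place of trifluoromethyl on an aromatic carbon, made at the same place and so the same change as before, now on the core of compound 3. Since that core is known only through a limit, the expectation for compound 4 carries the same uncertainty. Compound 4 is expected to give about 35000 nM in this assay, most likely between 8000 nM and 120000 nM. The step expected from compound 3 to compound 4 is an at least 1.4-fold lower number from compound 3 to compound 4 (0.15 log units; that floor lies within the scatter), which rests on the earlier measured step of a 4.0-fold lower number from compound 1 to compound 2 (0.60 log units; beyond the scatter) applied to the limit of compound 3.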

Compound 4, half-maximal inhibitory concentration: 2500 nM
Beside the measured number, compound 4's estimate is 14-fold (1.15 log units) above it; measured number below the stated range.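

In this assay, hydroxy in place of trifluoromethyl lowers the number on both cores, and on the core of compound 3 it gives an at least 20-fold lower number from compound 3 to compound 4 (1.30 log units; beyond the scatter), so the direction of the change carries over from one core to the other but its size does not: the same change on two cores in this assay, a 4.0-fold lower number (0.60 log units; beyond the scatter) from compound 1 to compound 2 and an at least 20-fold lower number (1.30 log units; beyond the scatter) from compound 3 to compound 4, at least 4.9-fold (0.69 log units) apart, beyond the scatter of two such steps The step on the core of compound 3 has only a floor, and its full size stays unknown, since compound 3 is known only through a limit and not a number: the limit of > 50000 nM in this assay, at which 1 of the 4 values shown sits.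

Two cores show no rule for a third, and these data do not explain why the step differs, although the two hydroxy compounds end up close together, with compound 2 at 2460 nM and compound 4 at 2500 nM.

The compounds shown leave open whether an amine, a carboxylic acid or a methoxy group could stand in the place of the hydroxy group and give a similar number. They also leave open whether the same change would behave as it does here on a core that carries a chlorophenyl or an unsubstituted phenyl group in place of the methoxy-bearing phenyl.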